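The source may report more compounds than this note shows. Statements on the series, on what has been measured and on what is new or still open speak of the compounds shown alone.

The shared core carries an aryl arm on a saturated chain carbon bound to an aromatic nitrogen, and three versions of that arm have been tested in an ADME assay on MDBK cells (Bos taurus) for cytotoxicity; on this read-out lower numbers stand for higher toxicity in this test and higher numbers for lower toxicity in this test. Compound 1 `Cc1cccc(Cn2ccc3nc(-c4ccccc4)nc-3c2)c1` carries 3-methylphenyl there. In this assay compound 1 gives > 100000 nM, which is a limit of the assay and not a number. Compound 2 `Fc1ccccc1Cn1ccc2nc(-c3ccccc3)nc-2c1` in this assay gives > 100000 nM, again a limit. Compound 3 `Clc1cccc(Cn2ccc3nc(-c4ccccc4)nc-3c2)c1` in this assay gives > 100000 nM, also a limit. Because (the limit of > 100000 nM in this assay, at which 3 of the 3 values shown sit), the three steps among them, a step that the two limits leave unreadable from compound 1 to compound 2, a step that the two limits leave unreadable from compound 1 to compound 3 and a step that the two limits leave unreadable from compound 2 to compound 3, cannot be read in size or direction. Compound 4 `N#Cc1ccccc1Cn1ccc2nc(-c3ccccc3)nc-2c1` has not yet been measured; it differs from compound 1 by 2-cyanophenyl in place of 3-methylphenyl on a saturated chain carbon bound to an aromatic nitrogen. For the measured compounds named here, the steps that bear on this change, those to 2-fluorophenyl and to 3-chlorophenyl, carry no readable size, so no step beyond the scatter can be foreseen in either direction, and a further limit is the most likely outcome. Compound 4 is therefore expected to give 150000 nM, within 50000 nM to 500000 nM. The expected step is a step that the limit leaves unreadable from compound 1 to compound 4.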

Compound 4, half-maximal cytotoxic concentration: > 100000 nM
Compound 4: no number, only a limit (the forecaster's own chance of this, stated with the estimate: 85%); the middle value is on the limit's open side.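

The steps from compound 4 to compound 1, compound 2 and compound 3 cannot be read in size or direction: the limit of > 100000 nM in this assay, at which 4 of the 4 values shown sit. The compounds shown leave open whether any aryl arm on the shared core gives a number rather than a limit in this assay and how the arms would then compare.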